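Swapping the five-membered ring on the core of compound 3

A few compounds are considered here, and "the series" means these few. Any claim that something is new, unique, unknown or untested is made for them only; others in the source may bear on it.

Of the compounds shown here, three that share one core have been measured in a functional assay on U-87MG ATCC cells for inhibition, with U-87 MG (Homo sapiens) as the target, read by MTT assay, with a stated time of 72 h; a lower number here means a stronger inhibitor, a higher number a weaker inhibitor. Compound 1 `Cc1noc(C)c1-c1cnc(N)c(Oc2ccc(C(=O)NC3CCCC3)cc2)n1` gives 57600 nM, compound 2 `Cc1noc(C)c1-c1cnc(N)c(Oc2ccc(C(=O)NC3CCCCC3)cc2)n1` gives 40400 nM, and compound 3 `Cc1noc(C)c1-c1cnc(N)c(Oc2ccc(C(=O)Nc3cccc(Cl)c3)cc2)n1` gives 11500 nM, the lowest number of the three. The changes among them all sit on the amide-type nitrogen: a 1.4-fold lower number from compound 1 to compound 2 (0.15 log units; within the scatter), while a 5.0-fold lower number from compound 1 to compound 3 (0.70 log units; beyond the scatter) and a 3.5-fold lower number from compound 2 to compound 3 (0.55 log units; beyond the scatter).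

Compound 4 `Cn1cc(-c2cnc(N)c(Oc3ccc(C(=O)Nc4cccc(Cl)c4)cc3)n2)cn1` keeps the amide of compound 3 and alters a different part of the molecule: 1-methyl-1H-pyrazol-4-yl in place of 3,5-dimethyl-1,2-oxazol-4-yl on an aromatic carbon. Among the compounds with values here, none of the measured steps touches this aromatic carbon of the shared core, so the numbers so far say nothing direct about how such a swap moves the result in this assay. The two rings are both five-membered aromatic rings with 2 hetero atoms and 2 hydrogen-bond acceptors, which makes a small change the most plausible expectation; compound 4 is expected to show a 1.0-fold higher number from compound 3 to compound 4 (0.02 log units; within the scatter). Compound 4 is therefore estimated at 12000 nM, with a range from 3000 nM to 50000 nM.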

Compound 4, half-maximal inhibitory concentration: 21700 nM
For compound 4 the middle estimate is 1.8-fold (0.26 log units) below the measured one; the range from low to high includes it.
By their numbers in this assay, from the lowest: compounds 3, 4, 2 and 1 (each within the scatter of the next, the first and the last beyond it).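

Within the data shown here, this is the first reading at the aromatic carbon para to an amino group. Replacing 3,5-dimethyl-1,2-oxazol-4-yl with 1-methyl-1H-pyrazol-4-yl in this assay gives a 1.9-fold higher number from compound 3 to compound 4 (0.28 log units; within the scatter), so this exchange of one five-membered aromatic ring with 2 hetero atoms for another cannot be told apart from repeat-measurement noise, at least alongside the 3-chlorophenyl amide. Nothing available explains this outcome or connects it to any property of the two rings.

The compounds shown leave open whether a quite different group on this carbon, such as a pyridine ring or a morpholine, would move the number beyond the scatter. They also leave open whether the same ring swap would read alike with the cyclopentyl amide of compound 1 or the cyclohexyl amide of compound 2.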